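The source may report more compounds than this note shows. Statements on the series, on what has been measured and on what is new or still open speak of the compounds shown alone.

Measured so far in a functional assay on MIA PaCa-2 cells (Homo sapiens) for inhibition, read by MTT assay, with a stated time of 7 days; a lower number here means a stronger inhibitor, a higher number a weaker inhibitor:
Compound 1 `CCC(CC)S(=O)(=O)c1ccc(S(=O)(=O)N2CCC[C@@H](C(=O)N3CCC(F)(F)CC3)C2)cc1` gives 13 nM in this assay.
Compound 2 `CCN(CC)S(=O)(=O)c1ccc(S(=O)(=O)N2CCC[C@@H](C(=O)NC3COC3)C2)cc1` gives 2340 nM in this assay.
Compound 3 `CCN(CC)S(=O)(=O)c1ccc(S(=O)(=O)N2CCC[C@@H](C(=O)N3CCOCC3)C2)cc1` gives 350 nM in this assay.

Compound 1 has the lowest number of the three, so it is the strongest inhibitor here; compound 3 stands nearest to it and compound 2 furthest, and both gaps are beyond the scatter.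

Compound 4 `CN(C)S(=O)(=O)c1ccc(S(=O)(=O)N2CCC[C@@H](C(=O)N3CCC(F)(F)CC3)C2)cc1` differs from compound 1 in one place: dimethylamino in place of pentan-3-yl on a sulfonyl sulfur. Among the compounds with values here, the only measured step, a 6.7-fold lower number from compound 2 to compound 3 (0.83 log units; beyond the scatter), concerns the group on the carbonyl carbon, not the sulfonyl sulfur, so it does not speak directly to this change. Compounds 2 and 3 both carry a diethylamino on that sulfur and both give higher numbers than compound 1, but they also differ from compound 1 at the carbonyl, so the share belonging to the sulfonyl group cannot be separated out. Within the data shown here, with a smaller group entering and no step that measures it, a modest rise beyond the scatter is expected rather than a large one.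

Compound 4 is therefore expected to give about 60 nM in this assay, within a range of 15 nM to 300 nM, meaning an expected step of a 4.6-fold higher number from compound 1 to compound 4 (0.66 log units; beyond the scatter).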

Compound 4, half-maximal inhibitory concentration: 118 nM
The estimate for compound 4 lay 2.0-fold (0.29 log units) below the measured number; measured number inside the range.
By their numbers in this assay, from the lowest: compound 1; then compound 4; then compound 3; then compound 2.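

In this assay, replacing pentan-3-yl with dimethylamino on the sulfonyl sulfur, with the rest of compound 1 unchanged, gives a 9.1-fold higher number from compound 1 to compound 4 (0.96 log units; beyond the scatter). Within the data shown here, this is the first direct measure of this position, and it shows that the group on the sulfonyl sulfur can by itself make a clear difference to the inhibition, as the earlier step showed only for the group on the carbonyl carbon. The swap changes two things at once, since the entering group is smaller by heavy-atom count and brings a nitrogen to the sulfur, and no measurement here accounts for the change in number or separates those two differences.

An isopropyl group on the same sulfur, which has the same heavy-atom count as dimethylamino but is all carbon, would help show whether size or the nitrogen matters more, and a longer chain than pentan-3-yl would show whether the number keeps falling as the group grows. As far as these compounds go, it also remains open whether this step would be the same size with morpholin-4-yl on the carbonyl carbon, since compound 3 differs from compound 1 in more than one place.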